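Isoquinoline amides: aryl variation at the amide-bearing carbon

The compounds below may be only part of what the source reports. "The series", "measured", "known", "first", "only" and "open" are said of these compounds alone.

Measured so far in an assay on isolated protein for inhibition of RAC-alpha serine/threonine-protein kinase (Homo sapiens); on this read-out higher numbers stand for weaker inhibition and lower numbers for stronger inhibition:
compound 1 `O=C(NC(c1ccc(F)c(F)c1)C1CCNCC1)c1ccc2cnccc2c1`: 2680 nM
compound 2 `O=C(NC(c1cccc(Cl)c1)C1CCNCC1)c1ccc2cnccc2c1`: 70 nM
compound 3 `O=C(NC(c1ccc(Cl)c(F)c1)C1CCNCC1)c1ccc2cnccc2c1`: 40 nM

Compound 3 gives the lowest of the three numbers in this assay; the steps that lead to it are a 1.8-fold lower number from compound 2 to compound 3 (0.24 log units; within the scatter) and a 67-fold lower number from compound 1 to compound 3 (1.83 log units; beyond the scatter). Compound 4 `O=C(NC(c1cnc(Cl)c(Cl)c1)C1CCNCC1)c1ccc2cnccc2c1` differs from compound 3 by 5,6-dichloropyridin-3-yl in place of 4-chloro-3-fluorophenyl on a saturated chain carbon bound to an amide-type nitrogen and a saturated ring carbon. Within the data shown here, no measured step covers a ring nitrogen in this group; the steps that bear on it are a 67-fold lower number from compound 1 to compound 3 (1.83 log units; beyond the scatter) and a 38-fold lower number from compound 1 to compound 2 (1.58 log units; beyond the scatter), both large, and a 1.8-fold lower number from compound 2 to compound 3 (0.24 log units; within the scatter), within the scatter. Two chloro groups remain, so no large move is expected. For compound 4 the estimate is 55 nM, range 15 nM to 200 nM. The expected step from compound 3 is a 1.4-fold higher number from compound 3 to compound 4 (0.14 log units; within the scatter), not beyond the scatter.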

Compound 4, half-maximal inhibitory concentration: 140 nM
Beside the measured number, compound 4's estimate is 2.5-fold (0.41 log units) below it, within the range that was stated.
By their numbers in this assay, from the lowest: compounds 3, 2 and 4 (each within the scatter of the next, the first and the last beyond it); then compound 1.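

In this assay, a ring with one hetero atom is accepted at this carbon, though not without cost: 5,6-dichloropyridin-3-yl gives a 3.5-fold higher number from compound 3 to compound 4 (0.54 log units; beyond the scatter), a modest step, and a 2.0-fold higher number from compound 2 to compound 4 (0.30 log units; within the scatter). It keeps much of the large difference from the difluorinated ring, with a 19-fold lower number from compound 1 to compound 4 (1.28 log units; beyond the scatter). No data on hand account for these steps.

This change swaps a fluoro group for a chloro group and also brings in the ring nitrogen, and the compounds shown do not separate the two. Also open, going by these compounds, is how a methoxy group or a nitrile on this ring would read.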